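The compounds below may be only part of what the source reports. "The series", "measured", "known", "first", "only" and "open" are said of these compounds alone.

Compound 1 `CC1CCN(c2c(S(=O)(=O)c3ccc(Cl)cc3)cnc3cc(F)ccc23)CC1` gives 90% in an assay on isolated protein for displacement of a labelled ligand from metabotropic glutamate receptor 5 (Homo sapiens), with a stated time of 60 min, tested at 1 uM; a lower number here means less inhibition, a higher number more inhibition at the concentration tested (going by the name of the read-out).
Compound 2 `Cc1cc(C)cc(S(=O)(=O)c2cnc3cc(F)ccc3c2N2CCC(C)CC2)c1` gives 80%.
Compound 3 `COc1cccc(S(=O)(=O)c2cnc3cc(F)ccc3c2N2CCC(C)CC2)c1` gives 90%.

Compound 3 stands level with compound 1 at the digits shown, the two together the highest of the three numbers, while compound 2 sits a number 10 percentage points higher from compound 2 to compound 3 (within the scatter), which is within the scatter. Compound 4 `COc1ccc(S(=O)(=O)c2cnc3cc(F)ccc3c2N2CCC(C)CC2)cc1OC` differs from compound 3 by methoxy in place of hydrogen on an aromatic carbon. Within the data shown here, the steps that bear on this change all alter the aryl on the sulfonyl sulfur: no change at the digits printed from compound 1 to compound 3 (within the scatter) and a number 10 percentage points higher from compound 2 to compound 3 (within the scatter), both within the scatter. A further change on that same aryl is therefore expected to give a number 5 percentage points lower from compound 3 to compound 4 (within the scatter), nothing beyond the scatter. Compound 4 is estimated at 85%, between 65% and 97%.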

Compound 4, a percentage reported as inhibition, at one concentration (the size of the read-out at that concentration, not a potency): 83%
For compound 4 the middle estimate is 2 percentage points above the measured one; the range from low to high includes it.
By their numbers in this assay, from the lowest: compounds 2, 4, 1 and 3 (each within the scatter of the next).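

Methoxy in place of hydrogen on the aromatic carbon ortho to a methoxy group and para to a large group gives a number 7 percentage points lower from compound 3 to compound 4 (within the scatter) in this assay, so this position takes the change from 3-methoxyphenyl to 3,4-dimethoxyphenyl without a step that stands out from the scatter. The new aryl on the sulfonyl sulfur also cannot be told apart from the two others, with a number 3 percentage points higher from compound 2 to compound 4 (within the scatter) and a number 7 percentage points lower from compound 1 to compound 4 (within the scatter) as the remaining steps. Nothing measured here offers an explanation for this result.

From the compounds shown here alone, whether an amine or a carboxylic acid at this position would keep the inhibition remains open, as does the effect of a longer chain in place of the added methoxy.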